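The source may report more compounds than this note shows. Statements on the series, on what has been measured and on what is new or still open speak of the compounds shown alone.

Measured compounds:
compound 1, `O=c1[nH]/c(=N\OCCCCc2ccccc2)ccn1[C@@H]1O[C@H](COP(=O)(O)OP(=O)(O)OP(=O)(O)O)[C@@H](O)[C@H]1O`: 214 nM in a functional assay on 1321-N1 cells for agonist activity at P2Y purinoceptor 2 (Homo sapiens), read by scintillation counting and inositol phosphate accumulation; on this read-out lower numbers stand for an effect already at smaller amounts and higher numbers for an effect only at larger amounts of compound
compound 2, `O=c1[nH]/c(=N\OCCCc2cccc(F)c2)ccn1[C@@H]1O[C@H](COP(=O)(O)OP(=O)(O)OP(=O)(O)O)[C@@H](O)[C@H]1O`: 190 nM in this assay

Of the two numbers shown, the one for compound 2 is the smaller, yet the step of a 1.1-fold lower number from compound 1 to compound 2 (0.05 log units; within the scatter) falls within the scatter, so compound 2 and compound 1 are not separated by these data.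

Compound 3, `O=c1[nH]/c(=N\OCCCc2ccc(Br)cc2)ccn1[C@@H]1O[C@H](COP(=O)(O)OP(=O)(O)OP(=O)(O)O)[C@@H](O)[C@H]1O`, carries the change 4-bromophenyl in place of 3-fluorophenyl on a saturated chain carbon, three bonds along the chain from an oxygen relative to compound 2. Going by the values given here, the only measured step at this position, a 1.1-fold lower number from compound 1 to compound 2 (0.05 log units; within the scatter), replaced benzyl by 3-fluorophenyl and produced nothing beyond the scatter. Among the compounds with values here, no measured pair swaps one substituted phenyl for another, so the effect of 4-bromophenyl in place of 3-fluorophenyl has no direct precedent here.

Given the flat step a 1.1-fold lower number from compound 1 to compound 2 (0.05 log units; within the scatter), the expected change is a 1.1-fold higher number from compound 2 to compound 3 (0.02 log units; within the scatter), with no direction favoured beyond the scatter. Compound 3 is estimated at 200 nM, with a range from 90 nM to 450 nM.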

Compound 3, half-maximal effective concentration: 350 nM
The estimate for compound 3 lay 1.8-fold (0.24 log units) below the measured number; the measured number falls inside the stated range.
By their numbers in this assay, from the lowest: compounds 2, 1 and 3 (each within the scatter of the next).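

Working notes on the series, read in this assay: the change to 4-bromophenyl gives a 1.8-fold higher number from compound 2 to compound 3 (0.27 log units; within the scatter) and, measured against the unsubstituted phenyl of compound 1, a 1.6-fold higher number from compound 1 to compound 3 (0.21 log units; within the scatter). The position on the saturated chain carbon, three bonds along the chain from an oxygen, therefore now has a second halogen-bearing phenyl group that these data do not separate from either earlier group, which extends the flat result that previously rested on 3-fluorophenyl alone. No supporting data bear on this result.

The swap from 3-fluorophenyl to 4-bromophenyl alters both the halogen and its place in the group's name, so the two contributions cannot be told apart here. Still open, from the compounds shown here alone, is whether an aminophenyl or carboxyphenyl group, or a longer chain, would stay within the scatter of these three compounds.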